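A few compounds are considered here, and "the series" means these few. Any claim that something is new, unique, unknown or untested is made for them only; others in the source may bear on it.

Of the two compounds measured in an assay for inhibition of Fatty-acid amide hydrolase 1 (Rattus norvegicus) (a lower number here means a stronger inhibitor, a higher number a weaker inhibitor), compound 1 `COC(=O)c1cccc(-c2cnc(C(O)CCc3ccc(-c4ccccc4)cc3)o2)n1` has the highest number, giving 9000 nM; compound 2 `O=C(CCc1ccc(-c2ccccc2)cc1)c1ncc(C(=O)C(F)(F)F)o1` gives 8 nM, a far lower number. Compound 3 `COC(=O)c1ccc(-c2cnc(C(O)CCc3ccc(-c4ccccc4)cc3)o2)nc1` carries 5-(methoxycarbonyl)pyridin-2-yl in place of 6-(methoxycarbonyl)pyridin-2-yl on an aromatic carbon: the two have the same atoms, joined differently. Going by the values given here, no measured step of this kind exists to lean on, and with the same groups in both, no step beyond the usual scatter is expected from this change. Compound 3 is therefore expected to land close by, at an estimated 9000 nM, between 3000 nM and 30000 nM. The expected step is no change at the digits printed from compound 1 to compound 3 (within the scatter).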

Compound 3, inhibition constant: 1100 nM
Compound 3: the middle estimate sits 8.2-fold (0.91 log units) above what was measured; the measured number lies below the stated range.
By their numbers in this assay, from the lowest: compound 2; then compound 3; then compound 1.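

In this assay, 5-(methoxycarbonyl)pyridin-2-yl in place of 6-(methoxycarbonyl)pyridin-2-yl gives an 8.2-fold lower number from compound 1 to compound 3 (0.91 log units; beyond the scatter). Compound 1 and compound 3 have the same atoms, so at this position how the group is joined alone changes the number beyond the scatter. Nothing shown gives a reason for this step.

Open, on these data alone, is whether a carboxylic acid or an amide in place of the methyl ester would keep or change the number of compound 3. Also open, as far as these compounds go, is whether a phenyl ring bearing the same ester would do the same as the pyridine.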